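The source may report more compounds than this note shows. Statements on the series, on what has been measured and on what is new or still open speak of the compounds shown alone.

Compound 1 `c1ccc(-c2ccc(-c3ccc(-c4nc5ccccc5[nH]4)cc3)cc2)cc1` gives 100000 nM
Compound 2 `COc1ccc(-c2ccc(-c3ccc(-c4nc5ccccc5[nH]4)cc3)cc2)cc1` gives 2760 nM

For the measured compounds named here, in a functional assay on SiHa cells (Homo sapiens) for inhibition, read by sulforhodamine B assay (a higher number here means a weaker inhibitor of growth, a lower number a stronger inhibitor of growth), compound 2 (2760 nM) holds the lower of the two numbers so far. Compound 3 `CN(C)c1ccc(-c2ccc(-c3ccc(-c4nc5ccccc5[nH]4)cc3)cc2)cc1` changes one group (dimethylamino in place of methoxy on an aromatic carbon): dimethylamino in place of methoxy on an aromatic carbon, para to a large group. Going by the values given here, the one measured step at this place (a 36-fold lower number from compound 1 to compound 2 (1.56 log units; beyond the scatter)) put methoxy in place of hydrogen and was large. Compound 3 instead swaps one group for another, so a much smaller step is expected, with no firm direction. In this assay the expected step (a 1.1-fold lower number from compound 2 to compound 3 (0.04 log units; within the scatter)) stays within the scatter. Compound 3 is expected at 2500 nM (600 nM to 10000 nM).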

Compound 3, concentration for 50% growth inhibition: 100000 nM
The estimate for compound 3 lay 40-fold (1.60 log units) below the measured number, outside the stated range (above it).
By their numbers in this assay, from the lowest: compound 2; then compounds 1 and 3 (each within the scatter of the next).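

In this assay, the growth inhibition gained with methoxy does not carry over to dimethylamino at this position on the end ring: the swap gives a 36-fold higher number from compound 2 to compound 3 (1.56 log units; beyond the scatter). Measured against hydrogen, dimethylamino gives no change at the digits printed from compound 1 to compound 3 (within the scatter), so here the outcome depends on which group is attached, not merely on hydrogen being replaced. No measurement available here accounts for the difference between these two groups. Going by these compounds, whether a hydroxyl, an ethoxy or a primary amine at this position would behave like methoxy or like dimethylamino remains open.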